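Half-life: Swapping a Benzoyl Ester for Nitrate

This account rests on a few compounds, and the source may have more. Where it says the series, first, only, none or still open, it means among the compounds named here.

Measured compounds:
- compound 1, `CC(=O)Oc1ccccc1C(=O)O[C@H]1CO[C@H]2[C@@H]1OC[C@H]2OC(=O)c1ccccc1`: 0.0107 h
- compound 2, `CC(=O)Oc1ccccc1C(=O)O[C@H]1CO[C@H]2[C@@H]1OC[C@H]2OC(=O)c1ccccc1C`: 0.0138 h

Within the data shown here, in an ADME assay on a cell-free system (plasma, Homo sapiens) for metabolic stability, with Plasma (Rattus norvegicus) as the target, read by HPLC, at pH 7.4 (a higher number here means that the compound lasts longer, a lower number that the compound disappears faster), compound 1 gives 0.0107 h, the lowest of the two numbers so far, while compound 2 gives 0.0138 h; the two lie within the scatter of each other. Compound 3, `CC(=O)Oc1ccccc1C(=O)O[C@H]1CO[C@H]2[C@@H]1OC[C@H]2O[N+](=O)[O-]`, has not yet been measured. It differs from compound 1 in one place: nitro in place of benzoyl on an oxygen on a saturated carbon. Among the measured compounds shown here, only one measured step exists to compare, a 1.3-fold higher number from compound 1 to compound 2 (0.11 log units; within the scatter), and it concerns a change on the aromatic ring, not the ester on the saturated carbon that is replaced here. Nothing measured therefore speaks directly to this change, and the shared core with its remaining esters is kept. The expectation is a number close to that of compound 1, with no step beyond the scatter: a 1.4-fold higher number from compound 1 to compound 3 (0.15 log units; within the scatter) is the estimated step. Compound 3 is estimated at 0.015 h, within 0.006 h to 0.04 h.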

Compound 3, half-life: 0.00314 h
For compound 3 the middle estimate is 4.8-fold (0.68 log units) above the measured one, outside the stated range (below it).
By their numbers in this assay, from the lowest: compound 3; then compounds 1 and 2 (each within the scatter of the next).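

In this assay, this position on the saturated carbon moves the number beyond the scatter: nitro in place of benzoyl gives a 3.4-fold lower number from compound 1 to compound 3 (0.53 log units; beyond the scatter), and nitro in place of (2-methylphenyl)carbonyl gives a 4.4-fold lower number from compound 2 to compound 3 (0.64 log units; beyond the scatter). The earlier methyl change on the aromatic ring did not show this, as a 1.3-fold higher number from compound 1 to compound 2 (0.11 log units; within the scatter) stays within the scatter, so compound 3 disappears faster than both compounds that carry an aromatic ester at this place. Nothing available explains why the number falls with this change.

The compounds shown leave open whether the lower number goes with nitro itself or with the loss of the aromatic ring. A non-aromatic group on the same oxygen, such as a hexanoyl chain or a carbamate, would help to separate these two readings.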